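Notes on cytotoxicity toward normal colon cells in one series

The source may hold more compounds than are shown below. What is called first, only, known or untested is meant among the compounds shown, and "the series" means these compounds.

Measured so far:
compound 1 `COc1ccc(/C=C\c2cc(OC)c(OC)c(OC)c2)cc1OCc1ccc(CN2CC(C(=O)O)C2)cc1` gives > 50000 nM
compound 2 `COc1ccc(/C=C\c2cc(OC)c(OC)c(OC)c2)cc1OCc1ccc(CN2CCCC[C@H]2C(=O)O)cc1` gives > 50000 nM
compound 3 `COc1ccc(/C=C\c2cc(OC)c(OC)c(OC)c2)cc1OCc1ccc(CN2CC[C@@H](O)C2)cc1` gives 53000 nM

In an ADME assay on NCM460 cells (Homo sapiens) for cytotoxicity, read by CCK-8 assay, with a stated time of 48 h (on this read-out lower numbers stand for stronger inhibition and higher numbers for weaker inhibition), compound 1 gives > 50000 nM, which is a limit of the assay and not a number. Compound 2 likewise gives only a limit in this assay, > 50000 nM. Compound 3 gives a number in this assay, 53000 nM. Compound 1 therefore stands at the limit, alongside one further value, as the limit of > 50000 nM in this assay, at which 2 of the 3 values shown sit, shows. The step that the two limits leave unreadable from compound 1 to compound 2 cannot be sized, and the same holds for a step that the limit leaves unreadable from compound 1 to compound 3 and for a step that the limit leaves unreadable from compound 2 to compound 3; none of the three steps yields a readable size.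

Compound 4 `COc1ccc(/C=C\c2cc(OC)c(OC)c(OC)c2)cc1OCc1ccc(C=O)cc1` differs from compound 1 by formyl in place of (3-carboxyazetidin-1-yl)methyl on an aromatic carbon. Among the compounds with values here, no measured step covers a change of this kind: the three steps recorded swap one ring-bearing group for another and are all unreadable, so they offer no direction for this assay. With every measured value at or near the limit, no step beyond the scatter is expected. Compound 4 is expected to give about 40000 nM in this assay, within a range of 10000 nM to 100000 nM. The expected step is an at least 1.2-fold lower number from compound 1 to compound 4 (0.09 log units; that floor lies within the scatter).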

Compound 4, half-maximal inhibitory concentration: 41000 nM
Estimate against measurement, compound 4: 1.0-fold (0.01 log units) below; the range from low to high includes it.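

In this assay, compound 4 is the first compound shown with no saturated nitrogen ring on this aromatic carbon, para to a large group, and the only readable comparison is a 1.3-fold lower number from compound 3 to compound 4 (0.11 log units; within the scatter). Swapping the whole (3-hydroxypyrrolidin-1-yl)methyl group for the much smaller formyl therefore leaves the read-out within the scatter, so on this pair neither the ring nor the nitrogen is needed for a number in this range. The steps to the two carboxylic acids, an at least 1.2-fold lower number from compound 1 to compound 4 (0.08 log units; that floor lies within the scatter) and an at least 1.2-fold lower number from compound 2 to compound 4 (0.08 log units; that floor lies within the scatter), give only floors resting on limits, so their full size stays unread: the limit of > 50000 nM in this assay, at which 2 of the 4 values shown sit.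

On these data alone, how a simple primary amine, a hydroxymethyl or a longer chain on the same aromatic carbon would read remains open, as does any change that might give a value clearly apart from the scatter. Also open, as far as these compounds go, is whether the carboxylic acid carried by compound 1 and compound 2 has any effect of its own in this read-out, as both compounds rest on a limit.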